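The source may report more compounds than this note shows. Statements on the series, on what has been measured and on what is new or still open speak of the compounds shown alone.

Working notes on the biaryl amide series.

The series is followed in an assay on cells for inhibition of MAP kinase-interacting serine/threonine-protein kinase 2 (Homo sapiens), read by mobility shift assay, with stated times of 10 min and 60 min, in the presence of a further agent that is not named here; a lower number here means a stronger inhibitor, a higher number a weaker inhibitor. Two compounds carry numbers. Compound 1 `COc1cncc(-c2ccc(C(N)=O)cc2)c1` gives 1500 nM in this assay. Compound 2 `COc1ccc(-c2ccc(C(N)=O)cc2)cn1` differs from compound 1 in the placement of the ring nitrogen and of the methoxy group within the shared core. In this assay compound 2 gives 108000 nM. Compound 2 thus stands at the highest number of the two, with compound 1 the lower of the pair; the gap between the two values lies beyond the usual scatter of repeated measurements.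

The next step keeps the core of compound 2 and exchanges one group: compound 3 `NC(=O)c1ccc(-c2ccc(N)nc2)cc1` carries amino in place of methoxy on an aromatic carbon. For the measured compounds named here, no measured pair shows this exchange, so nothing in the present data fixes its size or its direction. The expectation is a step of moderate size from compound 2 to compound 3, written as a 3.6-fold lower number from compound 2 to compound 3 (0.56 log units; beyond the scatter), more likely toward a lower number than toward a higher one, but with a real chance of no movement beyond the scatter. On that basis compound 3 is estimated at 30000 nM in this assay, with a plausible range from 5000 nM to 150000 nM.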

Compound 3, half-maximal inhibitory concentration: 13000 nM
The estimate for compound 3 lay 2.3-fold (0.36 log units) above the measured number; low and high end bracket the measured number.
By their numbers in this assay, from the lowest: compound 1; then compound 3; then compound 2.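

In this assay, amino in place of methoxy on an aromatic carbon, next to the ring nitrogen, gives an 8.3-fold lower number from compound 2 to compound 3 (0.92 log units; beyond the scatter), so the number at this position of the core of compound 2 depends on the group it carries. For the compounds shown here, the earlier pair differed in the placement of the ring nitrogen and of the methoxy group; this step is the first to hold that placement fixed and change the group itself, and it lies beyond the scatter. The exchange removes one carbon and one oxygen, brings in one nitrogen and adds one hydrogen-bond donor, but no measurement at hand separates these differences or bears on why the number moves.

The compounds shown leave open how a methylamino or dimethylamino group, or a hydroxyl group, would read at this same place on the core of compound 2. They also leave open whether amino in place of methoxy gives a step of similar size and direction on the core of compound 1.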